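Trading Isopropyl for Naphthalen-1-yl on a Ring Nitrogen

The source may hold more compounds than are shown below. What is called first, only, known or untested is meant among the compounds shown, and "the series" means these compounds.

Of the compounds shown here, three that share one core have been tested in a functional assay on CHO cells with adenosine receptor A1 (Homo sapiens) as the target, read by cAMP accumulation and immunoassay, with a stated time of 6 min, tested at 10 uM; a higher number here means a weaker effect of the compound at the concentration tested, a lower number a stronger effect. Compound 1 `CC(C)N1CCN(Cc2csc(N)c2C(=O)c2ccc(Cl)cc2)CC1` gives -7.4%, the highest of the three numbers, so it shows the weakest effect of the set. Compound 2 `Nc1scc(CN2CCN(c3ccc(Cl)cc3Cl)CC2)c1C(=O)c1ccc(Cl)cc1` gives -74%, and compound 3 `Nc1scc(CN2CCN(c3ccc(OC(F)(F)F)cc3)CC2)c1C(=O)c1ccc(Cl)cc1` gives -74%. The steps of a number 66.6 percentage points lower from compound 1 to compound 2 (beyond the scatter) and a number 66.6 percentage points lower from compound 1 to compound 3 (beyond the scatter) are both large, while the step of no change at the digits printed from compound 2 to compound 3 (within the scatter) shows that the two aromatic groups produced the same read-out.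

Compound 4 `Nc1scc(CN2CCN(c3cccc4ccccc34)CC2)c1C(=O)c1ccc(Cl)cc1` has not yet been measured. It differs from compound 1 in one place: naphthalen-1-yl in place of isopropyl on an amine nitrogen in a ring. Both measured steps away from compound 1 replaced the same isopropyl with an aromatic group on the same ring nitrogen, and each moved the number far downward. Naphthalen-1-yl is a third aromatic group in that position, so a step of the same kind is expected, downward and well beyond the scatter. Compound 4 is therefore estimated to give about -70%, with a likely range from -88% to -40%. This estimate means an expected step of a number 62.6 percentage points lower from compound 1 to compound 4 (beyond the scatter), close in size to the two measured steps from compound 1.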

Compound 4, a percentage reported as activity, at one concentration (the size of the read-out at that concentration, not a potency): -21%
The estimate for compound 4 lay 49 percentage points below the measured number; the measured number lies above the stated range.
By their numbers in this assay, from the lowest: compounds 2 and 3 (each within the scatter of the next); then compound 4; then compound 1.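

In this assay, an aromatic group on this ring nitrogen does not by itself guarantee a large drop, since naphthalen-1-yl in place of isopropyl gives only a modest step (a number 13.6 percentage points lower from compound 1 to compound 4 (beyond the scatter)). The choice of aromatic group matters as well: the steps (a number 53 percentage points higher from compound 3 to compound 4 (beyond the scatter)) and (a number 53 percentage points higher from compound 2 to compound 4 (beyond the scatter)) are both large, so the two substituted phenyl groups and the naphthalen-1-yl group, with its two six-membered aromatic rings of carbon only, are not interchangeable here. Nothing measured on these compounds accounts for this gap between the aromatic groups.

What stays open is which feature separates them: the compounds shown cannot tell whether the second ring of naphthalen-1-yl or the chlorine and trifluoromethoxy groups of the phenyl rings make the difference, and a plain phenyl, a naphthalen-2-yl or a benzyl group on the same nitrogen would help to separate these possibilities. All of these read-outs also come from a single concentration, so they leave open how the potencies of the compounds compare.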